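The source may report more compounds than this note shows. Statements on the series, on what has been measured and on what is new or still open speak of the compounds shown alone.

Working notes on the series. In a toxicity assay on the whole organism with Rattus norvegicus as the target, at a dose of 400 mg/kg by the oral route (a lower number here means a weaker effect, a higher number a stronger effect of the compound at the dose given), compound 1 `Clc1ccc(OCC2=NCCO2)cc1` gives 12%, compound 2 `Cc1ccccc1OCC1=NCCO1` gives 40% and compound 3 `Cc1cc(OCC2=NCCO2)ccc1Cl` gives 40%. The step of a number 28 percentage points higher from compound 1 to compound 3 (beyond the scatter) follows the change (methyl in place of hydrogen on an aromatic carbon). The difference between the cores of compound 1 and compound 2 is not broken down here; compound 2 and compound 3 stand level at the digits given.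

Compound 4 `Cc1ccc(OCC2=NCCO2)c(C)c1` is not yet measured. It carries the change (methyl in place of hydrogen on an aromatic carbon), the same kind of change as that from compound 1 to compound 3, though here the entering methyl sits meta to a methyl group and para to a group of 7 heavy atoms, rather than ortho to a chloro group and meta to a group of 7 heavy atoms. Set beside a number 28 percentage points higher from compound 1 to compound 3 (beyond the scatter), a step of a number 15 percentage points higher from compound 2 to compound 4 (beyond the scatter) is expected, resting on that single precedent at a different place. Compound 4 is therefore estimated at 55%, between 30% and 80%.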

Compound 4, a percentage reported as activity, at one dose (the size of the read-out at that dose, not a potency): 18%
Estimate against measurement, compound 4: 37 percentage points above; the whole stated range lies above it.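

In this assay the methyl in place of hydrogen on an aromatic carbon gives a number 22 percentage points lower from compound 2 to compound 4 (beyond the scatter), opposite in direction to the earlier step, so neither the size nor the direction of this change carries from one core to the other: the same change on two cores in this assay, a number 28 percentage points higher (beyond the scatter) from compound 1 to compound 3 and a number 22 percentage points lower (beyond the scatter) from compound 2 to compound 4, 50 percentage points apart, beyond the scatter of two such steps.

The two steps differ in the surroundings of the entering methyl as well as in the core, so these two effects cannot be separated here. Nor do two steps show why the direction differs, or give a rule for any further core.

The compounds shown leave open whether methyl would act alike at the same place on both cores. They also leave open how an ethyl group, a methoxy group or an amine on that aromatic carbon would read out in this assay.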